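Changing the Aryl Group on the Sulfonyl Sulfur

A few compounds are considered here, and "the series" means these few. Any claim that something is new, unique, unknown or untested is made for them only; others in the source may bear on it.

Compound 3 `CC1=NC(c2cn(S(=O)(=O)c3ccc(Cl)cc3)c3ccc(C)cc23)CN1` gives 1900 nM in an assay on isolated protein for inhibition of kallikrein-7 (Homo sapiens), read by fluorescence, with stated times of 10 min and 30 min; a higher number here means a weaker inhibitor, a lower number a stronger inhibitor. Among the numbers shown it is the lowest, ahead of compound 2 `CC1=NC(c2cn(S(=O)(=O)c3ccc(Cl)cc3)c3ccccc23)CN1`, which in this assay gives 5700 nM. Among the measured compounds shown here, the only measured step, a 3.0-fold lower number from compound 2 to compound 3 (0.48 log units; beyond the scatter), concerns a methyl in place of hydrogen on an aromatic carbon of the shared core. For the measured compounds named here, compound 1 `Cc1ccc(S(=O)(=O)n2cc(C3CNC(C4CCCCC4)=N3)c3ccccc32)cc1` differs from compound 3 in two places at once, and no step is drawn to it. In this assay compound 1 gives > 100000 nM, which is a limit of the assay and not a number (the limit of > 100000 nM in this assay, at which 1 of the 3 values shown sits).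

Compound 4 `CC1=NC(c2cn(S(=O)(=O)c3ccccc3C)c3ccc(C)cc23)CN1` differs from compound 3 by 2-methylphenyl in place of 4-chlorophenyl on a sulfonyl sulfur. Going by the values given here, no measured step alters the group on the sulfonyl sulfur, and the core step a 3.0-fold lower number from compound 2 to compound 3 (0.48 log units; beyond the scatter) does not bear on this change. The change is therefore expected to bring a small step, a 1.8-fold higher number from compound 3 to compound 4 (0.27 log units; within the scatter), with wide uncertainty. Compound 4 is expected to give 3500 nM in this assay, between 800 nM and 15000 nM.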

Compound 4, half-maximal inhibitory concentration: 1000 nM
For compound 4 the middle estimate is 3.5-fold (0.54 log units) above the measured one; low and high end bracket the measured number.
By their numbers in this assay, from the lowest: compounds 4 and 3 (each within the scatter of the next); then compound 2. At a limit, above all of these: compound 1.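

The step at the sulfonyl sulfur, a 1.9-fold lower number from compound 3 to compound 4 (0.28 log units; within the scatter), is the only one shown at this position, and it leaves 2-methylphenyl and 4-chlorophenyl indistinguishable in this assay. The two groups have the same heavy-atom count and each is one six-membered aromatic ring of carbon only, so the chlorine of compound 3 is not needed to hold the number at this level, as compound 4 carries none. Nothing shown here explains why the two groups match.

Open, from the compounds shown here alone, is whether a phenyl ring bearing an amine or a carboxylic acid, or a butyl chain in place of the aryl group on the sulfonyl sulfur, would stay within the scatter of compound 3 in this assay. Also open, going by these compounds, is whether the core step, a 3.0-fold lower number from compound 2 to compound 3 (0.48 log units; beyond the scatter), would recur with 2-methylphenyl on the sulfonyl sulfur.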